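Replacing the 3-chlorophenyl group on a carbonyl carbon

The source may report more compounds than this note shows. Statements on the series, on what has been measured and on what is new or still open speak of the compounds shown alone.

Compound 1 `C[C@@H](NCc1ccc(Cl)cc1)[C@H]1CC[C@@H](c2ccnc3ccc(F)cc32)CC1`: 34%
Compound 2 `C[C@@H](NS(=O)(=O)c1ccc(Cl)cc1)[C@H]1CC[C@@H](c2ccnc3ccc(F)cc32)CC1`: 29%
Compound 3 `C[C@@H](NC(=O)c1cccc(Cl)c1)[C@H]1CC[C@@H](c2ccnc3ccc(F)cc32)CC1`: 39%

In an ADME assay on microsomes from liver (Homo sapiens) for metabolic stability, with a stated time of 10 min, tested at 0.5 uM (on this read-out higher numbers stand for a more stable compound and lower numbers for a less stable compound), compound 3 gives 39%, which does not set it apart, as compound 1 and compound 2 both lie within the scatter of it. Compound 4 `C[C@@H](NC(=O)C12CCC(Cl)(CC1)CC2)[C@H]1CC[C@@H](c2ccnc3ccc(F)cc32)CC1` has not yet been measured. It keeps the shared core of compound 3 and differs in one place: a group of 9 heavy atoms (8 carbon, 1 chlorine; 2 six-membered non-aromatic rings of carbon only) in place of a group of 7 heavy atoms (6 carbon, 1 chlorine; one six-membered aromatic ring of carbon only), on a carbonyl carbon.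

Two measured steps end at compound 3, and both change the group on the same amine nitrogen. They are a number 5 percentage points higher from compound 1 to compound 3 (within the scatter) and a number 10 percentage points higher from compound 2 to compound 3 (within the scatter). In both, an aromatic ring remains in the new group, so neither tests the loss of that ring, and the evidence is indirect. On these steps, no change beyond the scatter is expected, in either direction. The expected step is a number 4 percentage points lower from compound 3 to compound 4 (within the scatter). Compound 4 is estimated at 35%, with an expected range from 18% to 55%.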

Compound 4, percent of the compound remaining: 9%
Estimate against measurement, compound 4: 26 percentage points above; the measured number lies below the stated range.
By their numbers in this assay, from the lowest: compound 4; then compounds 2, 1 and 3 (each within the scatter of the next).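

In this assay, among the compounds shown here, the change on the carbonyl carbon gives a number 30 percentage points lower from compound 3 to compound 4 (beyond the scatter), the only step in this set that lies beyond the scatter. The earlier steps shown here changed the group on the amine nitrogen and kept an aromatic ring in it, whereas this step replaces the 3-chlorophenyl with two six-membered non-aromatic rings of carbon only, so it shows that the read-out can move with the group at this position. Nothing given here accounts for the lower number.

The aromatic ring and the heavy-atom count change together in this one step, so the compounds shown do not separate the two. As far as these compounds go, a plain cyclohexyl group on the same carbonyl carbon, or the same two-ring group carrying a carboxylic acid in place of its chlorine, remains open.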